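The compounds below may be only part of what the source reports. "The series", "measured", "known", "first", "only" and "open" are said of these compounds alone.

Measured compounds, cytotoxicity read-out in a functional assay on RPMI 8402 cells (Homo sapiens) for cytotoxicity; on this read-out higher numbers stand for weaker inhibition and lower numbers for stronger inhibition:
- compound 1 `NC(=O)c1ccc2[nH]c(-c3ccc4[nH]c(-c5ccc6ccccc6c5)nc4c3)nc2c1` gives 740 nM
- compound 2 `Cc1cccc(-c2nc3cc(-c4nc5cc(N6CCN(C)CC6)ccc5[nH]4)ccc3[nH]2)c1` gives 360 nM
- compound 3 `CN1CCN(c2ccc3[nH]c(-c4ccc5[nH]c(-c6cccc7ccccc67)nc5c4)nc3c2)CC1` gives 330 nM

Compound 3 shows the lowest of the three numbers in this assay; its nearest neighbour is compound 2, whose number lies within the scatter of it, and the furthest is compound 1, whose number is higher beyond the scatter. For the measured compounds named here, the one measured step that reaches compound 3, a 1.1-fold lower number from compound 2 to compound 3 (0.04 log units; within the scatter), is within the scatter, so swapping the aryl group attached between the two ring nitrogen atoms has so far left the number unchanged.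

Compound 4 `CN1CCN(c2ccc3[nH]c(-c4ccc5[nH]c(-c6ccc7ccccc7c6)nc5c4)nc3c2)CC1` differs from compound 3 only by naphthalen-2-yl in place of naphthalen-1-yl on an aromatic carbon. Going by the values given here, no measured pair isolates this change. Compound 1 carries the naphthalen-2-yl group too, but it differs from compound 3 in a second group as well, so its value can only be noted alongside that of compound 3, not read as a step. Given that the only comparable aryl swap was flat, the expected step of a 1.2-fold higher number from compound 3 to compound 4 (0.08 log units; within the scatter) is small, with no direction beyond the scatter. Compound 4 is expected near 400 nM, in the range 200 nM to 800 nM.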

Compound 4, half-maximal inhibitory concentration: 110 nM
Compound 4: middle estimate off by 3.6-fold (0.56 log units), on the high side; the measured number lies below the stated range.
By their numbers in this assay, from the lowest: compound 4; then compounds 3 and 2 (each within the scatter of the next); then compound 1.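

In this assay, the aromatic carbon between two ring nitrogen atoms proves sensitive to the aryl group after all: with the same atoms joined differently, naphthalen-2-yl in place of naphthalen-1-yl gives a 3.0-fold lower number from compound 3 to compound 4 (0.48 log units; beyond the scatter), whereas the earlier swap gave only a 1.1-fold lower number from compound 2 to compound 3 (0.04 log units; within the scatter). Naphthalen-2-yl in place of 3-methylphenyl gives a 3.3-fold lower number from compound 2 to compound 4 (0.51 log units; beyond the scatter), so of the three aryl groups carried with 4-methylpiperazin-1-yl, naphthalen-2-yl alone stands apart, and with naphthalen-2-yl held constant, 4-methylpiperazin-1-yl in place of carbamoyl gives a 6.7-fold lower number from compound 1 to compound 4 (0.83 log units; beyond the scatter). Nothing available explains why the attachment point of the naphthalene matters.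

From the compounds shown here alone, it remains open whether naphthalen-2-yl keeps its edge over naphthalen-1-yl when carbamoyl replaces 4-methylpiperazin-1-yl. Also open, going by these compounds, is whether a primary amine or a carboxylic acid at that place would follow either group.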